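The compounds below may be only part of what the source reports. "The series", "measured", "known", "first", "only" and "open" are said of these compounds alone.

Compound 1, `CC(C)=CC[C@@H](OC[C@@H](C)O)C1=CC(=O)c2c(O)ccc(O)c2C1=O`, in a functional assay on HeLa cells (Homo sapiens) for cytotoxicity, read by MTT assay (a lower number here means a stronger inhibitor, a higher number a weaker inhibitor), gives 22500 nM.
Compound 2, `CC(C)=CC[C@@H](OC(=O)CC(C)(O)C(C)C)C1=CC(=O)c2c(O)ccc(O)c2C1=O`, in this assay gives 27700 nM.

On these two numbers compound 2 cannot be set apart from compound 1: the step of a 1.2-fold higher number from compound 1 to compound 2 (0.09 log units; within the scatter) lies within the scatter, so the two compounds stand together.

Compound 3, `CC(C)=CC[C@@H](OC(=O)C1CCCOC1)C1=CC(=O)c2c(O)ccc(O)c2C1=O`, differs from compound 2 in one place: oxan-3-yl in place of 2-hydroxy-2,3-dimethylbutyl on a carbonyl carbon. Going by the values given here, the only measured step, a 1.2-fold higher number from compound 1 to compound 2 (0.09 log units; within the scatter), also changed the group carried on the oxygen on the saturated carbon, and it did not move the number beyond the scatter. Among the compounds with values here, the oxan-3-yl group itself has no measured counterpart here, so the expectation rests on that single step alone and is loose.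

Compound 3 is therefore expected to stay close to compound 2, with a step of about a 1.1-fold lower number from compound 2 to compound 3 (0.04 log units; within the scatter), and its estimated value in this assay is 25000 nM, within a range from 10000 nM to 60000 nM.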

Compound 3, half-maximal inhibitory concentration: 60500 nM
Compound 3: middle estimate off by 2.4-fold (0.38 log units), on the low side; the whole stated range lies below it.
By their numbers in this assay, from the lowest: compounds 1 and 2 (each within the scatter of the next); then compound 3.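

In this assay, the group on the carbonyl carbon now makes a measurable difference: oxan-3-yl in place of 2-hydroxy-2,3-dimethylbutyl gives a 2.2-fold higher number from compound 2 to compound 3 (0.34 log units; beyond the scatter) and is the first step shown to pass beyond the scatter, though only modestly. The wider change, (oxan-3-yl)carbonyl in place of 2-hydroxypropyl on the oxygen on a saturated carbon, gives a 2.7-fold higher number from compound 1 to compound 3 (0.43 log units; beyond the scatter) as a similarly modest step, so this position is not as indifferent to its substituent as the earlier pair suggested. No available evidence bears on what lies behind this shift.

The change replaces an open hydroxy-bearing chain with an oxygen-containing ring, so the compounds shown leave open which of these features governs the number. A cyclohexyl ring or a piperidine ring on the same carbonyl carbon would help to separate them.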